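The source may report more compounds than this note shows. Statements on the series, on what has been measured and on what is new or still open speak of the compounds shown alone.

Working notes on the series. In an ADME assay on microsomes from liver (Mus musculus) for metabolic stability, read by LC-MS, using NADPH, with stated times of 5 min and 30 min, tested at 1 uM (on this read-out lower numbers stand for slow clearance and higher numbers for fast clearance), compound 2 `CC(c1ccc2ncc(-c3ccc(F)cc3)cc2c1)n1nnc2ncc(-c3ccncc3)nc21` gives 65 uL/min, and compound 3 `CC(c1ccc2ncc(-c3cnn(C)c3)cc2c1)n1nnc2ncc(-c3ccc(C(N)=O)c(F)c3)nc21` gives 30 uL/min. In this assay compound 1 `C[C@@H](c1cc2cccnc2cc1F)n1cnc2ncc(-c3cnn(C)c3)nc21` has no result reported. On these two numbers compound 3 stands lowest; compound 2 lies higher, and the gap between them is beyond the scatter. Compound 4 `CC(c1ccc2ncc(-c3cnn(C)c3)cc2c1)n1nnc2ncc(-c3ccncc3)nc21` is unmeasured and differs from compound 3 by pyridin-4-yl in place of 4-carbamoyl-3-fluorophenyl on an aromatic carbon. Compound 4 thus shares the pyridin-4-yl group with compound 2 and the rest of its structure with compound 3. For the measured compounds named here, no step between measured compounds covers this change, so the expected step is a 1.5-fold higher number from compound 3 to compound 4 (0.18 log units; within the scatter), a modest rise that may stay within the scatter. For compound 4 the estimate in this assay is 45 uL/min, with a range from 25 uL/min to 85 uL/min.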

Compound 4, intrinsic clearance in a liver preparation (reported as CLH), per the amount of preparation that the assay uses: 78 uL/min
Compound 4: the middle estimate sits 1.7-fold (0.24 log units) below what was measured; the range from low to high includes it.
By their numbers in this assay, from the lowest: compound 3; then compounds 2 and 4 (each within the scatter of the next).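

In this assay, with the rest of the structure held, pyridin-4-yl in place of 4-carbamoyl-3-fluorophenyl gives a 2.6-fold higher number from compound 3 to compound 4 (0.41 log units; beyond the scatter), so clearance responds to the group at this position. With pyridin-4-yl held, 1-methyl-1H-pyrazol-4-yl in place of 4-fluorophenyl gives a 1.2-fold higher number from compound 2 to compound 4 (0.08 log units; within the scatter), a change that stays within the scatter. No supporting data bear on the reason for the larger step. The compounds shown do not separate the contribution of the carbamoyl group from that of the fluorine. Going by these compounds, how a carboxylic acid or a morpholine would read at this position remains open.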